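Pyrazole to phenyl on the butyl amide chain

A few compounds are considered here, and "the series" means these few. Any claim that something is new, unique, unknown or untested is made for them only; others in the source may bear on it.

Values in a physicochemical assay for solubility, read by turbidimetry, measured as kinetic solubility, at pH 6.8; a lower number here means a less soluble compound, a higher number a more soluble compound:
- compound 1 `COc1ccc(F)cc1N1C(=O)CSC1c1cccc(C(=O)NCCCCc2ccccc2)c1`: 10000 nM
- compound 2 `O=C(NCCCCn1cccn1)c1cccc(C2SCC(=O)N2c2ccccn2)c1`: 50000 nM
- compound 3 `Cc1ccnc(N2C(=O)CSC2c2cccc(C(=O)NCCCCn3cccn3)c2)c1`: 50000 nM

Compound 2, at 50000 nM, stands level with compound 3 at 50000 nM, and together they hold the highest number of the three. Compound 1 stands lower, at 10000 nM.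

The step to compound 4 `O=C(NCCCCc1ccccc1)c1cccc(C2SCC(=O)N2c2ccccn2)c1` is phenyl in place of 1H-pyrazol-1-yl on a saturated chain carbon, four bonds along the chain from an amide-type nitrogen. Among the compounds with values here, the one measured step, no change at the digits printed from compound 2 to compound 3 (within the scatter), is methyl in place of hydrogen on an aromatic carbon, at another place in the molecule, so it offers no direct size for this swap. The best guide is compound 1 at 10000 nM, which has phenyl on the same chain but also carries a different group on the shared core. Its gap to compound 2 therefore cannot be assigned to the phenyl alone, and only part of that gap is expected to carry over in this assay.

The expected change is a 3.3-fold lower number from compound 2 to compound 4 (0.52 log units; beyond the scatter), towards a lower number. Compound 4 is estimated at 15000 nM, with an expected range of 5000 nM to 50000 nM.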

Compound 4, solubility: 20000 nM
For compound 4 the middle estimate is 1.3-fold (0.12 log units) below the measured one; the measured number falls inside the stated range.
By their numbers in this assay, from the lowest: compounds 1 and 4 (each within the scatter of the next); then compounds 2 and 3 (each within the scatter of the next).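

Read on its own, with the rest of compound 2 unchanged, phenyl in place of 1H-pyrazol-1-yl on the saturated chain carbon gives a 2.5-fold lower number from compound 2 to compound 4 (0.40 log units; beyond the scatter) in this assay, a modest step that compound 1 could not isolate. With phenyl held on the chain, pyridin-2-yl in place of 5-fluoro-2-methoxyphenyl on the amide-type nitrogen in a ring gives a 2.0-fold higher number from compound 1 to compound 4 (0.30 log units; within the scatter), so that swap does not separate the two compounds in this assay. No available measurement bears on the reason for either step.

Still open, going by these compounds, is whether the chain swap has the same size with 5-fluoro-2-methoxyphenyl on the ring nitrogen. Also open, on these data alone, is how this assay responds to an amine or a carboxylic acid at the end of the chain, or to a longer chain.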